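A Second Methyl on the Shared Core

A few compounds are considered here, and "the series" means these few. Any claim that something is new, unique, unknown or untested is made for them only; others in the source may bear on it.

compound 1 `COc1cc(OC)c2c(c1)OC(c1cccc(O)c1O)C(O)C2=O`: 57600 nM
compound 2 `O=C1c2ccccc2O[C@@H](c2cccc(O)c2O)[C@@H]1O`: > 100000 nM
compound 3 `Cc1ccc2c(c1)OC(c1cccc(O)c1O)C(O)C2=O`: 31800 nM

In a functional assay on RAW264.7 cells (Rattus norvegicus) for inhibition, with RAW264.7 (Mus musculus) as the target, read by Griess assay, with stated times of 2 h and 16 h (on this read-out higher numbers stand for weaker inhibition and lower numbers for stronger inhibition), compound 3 holds the lower of the two numbers, and compound 1 sits close by with 57600 nM, a gap that stays within the usual scatter, so neither can be called the stronger. Compound 2 gives only a limit of the assay, > 100000 nM, and no number (the limit of > 100000 nM in this assay, at which 1 of the 3 values shown sits). Compound 4 `Cc1cc2c(cc1C)C(=O)C(O)C(c1cccc(O)c1O)O2` differs from compound 3 by methyl in place of hydrogen on an aromatic carbon. For the measured compounds named here, no pair among the measured compounds shows such a step, so nothing measured tells its size; the expectation is a step in this assay no larger than the scatter, in no firm direction. Compound 4 is therefore estimated at 26000 nM, ranging from 8000 nM to 85000 nM, an expected step of a 1.2-fold lower number from compound 3 to compound 4 (0.09 log units; within the scatter).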

Compound 4, half-maximal inhibitory concentration: 20700 nM
For compound 4 the middle estimate is 1.3-fold (0.10 log units) above the measured one; the measured number falls inside the stated range.
By their numbers in this assay, from the lowest: compounds 4, 3 and 1 (each within the scatter of the next, the first and the last beyond it). At a limit, above all of these: compound 2.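

In this assay, for the compounds shown here, the first measured step for methyl in place of hydrogen on an aromatic carbon is a 1.5-fold lower number from compound 3 to compound 4 (0.19 log units; within the scatter) and it comes at a carbon ortho to a methyl group. Going by these compounds alone, a second methyl can therefore sit at this position without a change that stands clear of the scatter, which no earlier pair of compounds could show.

On these data alone, whether an amine or a carboxylic acid on this same carbon would give a larger step stays open. Nothing measured here explains the size of this step.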